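The source may hold more compounds than are shown below. What is called first, only, known or untested is meant among the compounds shown, and "the series" means these compounds.

Four compounds sharing one core were examined in an ADME assay on HEK-293T cells (Homo sapiens) for cytotoxicity, read by luminescence and CellTiter-Glo, with a stated time of 24 h; on this read-out lower numbers stand for higher toxicity in this test and higher numbers for lower toxicity in this test. Compound 1 `CCCNC(=O)C1CC12CCN(C(=O)c1cc3sc(-c4ccccc4)nc3n1Cc1ccc(OC)cc1)CC2` reaches (the limit of > 100000 nM in this assay, at which 1 of the 3 values shown sits), so its reading of > 100000 nM is a limit of the test and not a number. Compound 2 `CCCNC(=O)C1CC12CCN(C(=O)c1cc3sc(Br)nc3n1Cc1ccc(OC)cc1)CC2` gives 81300 nM. The move an at least 1.2-fold lower number from compound 1 to compound 2 (0.08 log units; that floor lies within the scatter) accompanies (bromo in place of phenyl on an aromatic carbon). Compound 3 `CCCNC(=O)C1CCN(C(=O)c2cc3sc(-c4ccccc4)nc3n2Cc2ccc(OC)cc2)CC1` gives 22900 nM; how its core differs from the core of compound 1 is not broken down here. Compound 4 `CCCNC(=O)C1CCN(C(=O)c2cc3sc(Br)nc3n2Cc2ccc(OC)cc2)CC1` has not yet been measured and carries the same change relative to compound 3, namely (bromo in place of phenyl on an aromatic carbon). Because an at least 1.2-fold lower number from compound 1 to compound 2 (0.08 log units; that floor lies within the scatter) stayed within the scatter, the expected step here is a 1.1-fold lower number from compound 3 to compound 4 (0.06 log units; within the scatter), estimated from that earlier move. Compound 4 is therefore expected to give about 20000 nM in this assay, with the real value likely falling between 8000 nM and 60000 nM.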

Compound 4, half-maximal cytotoxic concentration: 36700 nM
For compound 4 the middle estimate is 1.8-fold (0.26 log units) below the measured one; measured number inside the range.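

On the core of compound 3, swapping phenyl for bromo gives a 1.6-fold higher number from compound 3 to compound 4 (0.20 log units; within the scatter) in this assay, so this swap leaves no difference that stands out from the usual scatter of repeated measurements. Set beside the same swap on the other core, the comparison reads: the same change on two cores in this assay, an at least 1.2-fold lower number (0.08 log units; that floor lies within the scatter) from compound 1 to compound 2 and a 1.6-fold higher number (0.20 log units; within the scatter) from compound 3 to compound 4; the limit leaves it open whether they differ. Compound 1 gives a limit of the test and not a number, so the size of its step stays unknown and a match between the two cores is neither shown nor ruled out: the limit of > 100000 nM in this assay, at which 1 of the 4 values shown sits.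

Only phenyl and bromo appear at this place among the compounds shown. On these data alone, what an amine or a carboxylic acid there would give on either core stays open.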